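From 3-hydroxyphenyl to 4-fluorophenyl on a shared core

This account rests on a few compounds, and the source may have more. Where it says the series, first, only, none or still open, it means among the compounds named here.

In a functional assay on HCT-116 cells (Homo sapiens) for antiproliferative activity, read by CellTiter-Glo, with a stated time of 72 h (a lower number here means a stronger inhibitor, a higher number a weaker inhibitor), compound 1 `O=C(NO)c1cccc(/C=C/c2ccnc(-c3cc(F)ccc3O)c2)c1` gives 3890 nM while compound 2 `O=C(NO)c1ccc(/C=C/c2ccnc(-c3cccc(O)c3)c2)cc1` gives 1610 nM as the lower of the two numbers, a gap beyond the usual scatter. These two compounds differ in more than one place, so their gap cannot be assigned to any single change.

Compound 3 `O=C(NO)c1ccc(/C=C/c2ccnc(-c3ccc(F)cc3)c2)cc1` differs from compound 2 in one place only, and the change is counted here: 4-fluorophenyl in place of 3-hydroxyphenyl on an aromatic carbon. It has 4-fluorophenyl in place of 3-hydroxyphenyl on an aromatic carbon, next to the ring nitrogen.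

Among the compounds with values here, no measured pair in this assay shows this exchange, so the data offer no direction for it. The expected change a 1.1-fold lower number from compound 2 to compound 3 (0.03 log units; within the scatter) is therefore estimated to stay within the scatter. Within the data shown here, this expectation starts from compound 2 at 1610 nM as the only compound that differs from compound 3 in a single place, and the range is kept wide. For compound 3 the estimated value is 1500 nM with an expected range from 500 nM to 4500 nM as its likely span.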

Compound 3, half-maximal inhibitory concentration: > 10000 nM
Compound 3 was reported as a limit (the forecaster's own chance of this, stated with the estimate: 3%); middle value at least 6.6-fold (0.82 log units) away from the limit.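

In this assay compound 3 gives > 10000 nM, which is a limit of the assay and not a number. Replacing 3-hydroxyphenyl with 4-fluorophenyl on this aromatic carbon, next to the ring nitrogen, gives an at least 6.2-fold higher number from compound 2 to compound 3 (0.79 log units; beyond the scatter), so activity at this position depends on which aryl group it carries, something compound 1 and compound 2 could not show because they differ in more than one place. The step gives only a minimum for the loss, and its full size stays unknown: the limit of > 10000 nM in this assay, at which 1 of the 3 values shown sits.

The compounds shown leave open whether the step follows from the departure of the hydroxyl group, the arrival of the fluorine or the shift in where the substituent sits on the phenyl ring, since all of these happen together in this single exchange. Unsubstituted phenyl, 4-hydroxyphenyl or 3-fluorophenyl on the same core would separate these changes, while 3-aminophenyl or 3-methoxyphenyl would test whether a group other than hydroxyl can take its place.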